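Chloro substitution on the cyclopropylamide of this series

The source may report more compounds than this note shows. Statements on the series, on what has been measured and on what is new or still open speak of the compounds shown alone.

Two compounds have numbers in a toxicity assay on the whole organism (strain Icem-CET (SPF Caw)) for cytotoxicity, with Mus musculus as the target; on this read-out lower numbers stand for an effect already at smaller amounts and higher numbers for an effect only at larger amounts of compound. Compound 1 `C=CCNC(=O)/C(C)=C(/C)c1ccc(Cl)cc1` gives 400 mg/kg in this assay. Compound 2 `C/C(C(=O)NC1CC1)=C(\C)c1ccccc1` gives 300 mg/kg in this assay, the lower of the two numbers; compound 1 stands nearest, and its number is higher by an amount within the scatter, so the two read as alike. Among the compounds with values here, no step between compounds that differ in one place is available. Compound 3 `C/C(C(=O)NC1CC1)=C(\C)c1ccc(Cl)cc1` is the next member: the change from compound 2 is chloro in place of hydrogen on an aromatic carbon. Compound 1 already carries the chloro on a differently substituted amide and gives a number alike to compound 2, so the step from compound 2 to compound 3 in this assay is expected to be none beyond the scatter, a 1.1-fold higher number from compound 2 to compound 3 (0.04 log units; within the scatter). Compound 3 is therefore estimated at 330 mg/kg, in the range 180 mg/kg to 600 mg/kg.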

Compound 3, dose for half-maximal effect: 600 mg/kg
Beside the measured number, compound 3's estimate is 1.8-fold (0.26 log units) below it, and the stated range covers the measured number.
By their numbers in this assay, from the lowest: compounds 2, 1 and 3 (each within the scatter of the next).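

In this assay, chloro in place of hydrogen on an aromatic carbon, para to a large group, gives a 2.0-fold higher number from compound 2 to compound 3 (0.30 log units; within the scatter) and so leaves this position without a step beyond the scatter. Within the data shown here, with the chloro held constant, cyclopropyl in place of allyl on an amide-type nitrogen gives a 1.5-fold higher number from compound 1 to compound 3 (0.18 log units; within the scatter), a first one-place reading of the amide side, which also stays within the scatter. Nothing available bears on the reasons for either step.

Going by these compounds, whether a different group at this position, such as methoxy or a carboxylic acid, would give a step beyond the scatter remains open. Also open, on these data alone, is whether a longer chain or a chain carrying an amine on the amide nitrogen would move the number in this assay beyond the scatter.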